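From a 3-bromophenyl to a 4-fluorophenyl group

The source may hold more compounds than are shown below. What is called first, only, known or untested is meant among the compounds shown, and "the series" means these compounds.

Compound 1, `COc1cc(OC)c(OC)cc1/C=C/COC(=O)/C=C/c1ccc(OC)c(OC)c1`: 100%
Compound 2, `COc1cc(OC)c(OC)cc1/C=C/COC(=O)/C=C/c1ccc(Br)cc1`: 100%
Compound 3, `COc1cc(OC)c(OC)cc1/C=C/COC(=O)/C=C/c1cccc(Br)c1`: 100%

All three compounds were tested in a functional assay on the whole organism (strain Kunming) with Mus musculus as the target, with a stated time of 0.5 h, at a dose of 100 mg/kg by the intraperitoneal route; a lower number here means a stronger effect, a higher number a weaker effect of the compound at the dose given. Compound 3 stands level with compounds 1 and 2; its nearest neighbour is compound 1 and its furthest compound 2, and neither gap goes beyond the scatter. The measured steps agree: no change at the digits printed from compound 1 to compound 2 (within the scatter), no change at the digits printed from compound 1 to compound 3 (within the scatter) and no change at the digits printed from compound 2 to compound 3 (within the scatter). Every one of them exchanges the group on a double-bonded chain carbon bound to a double-bonded chain carbon, and every one leaves this assay unchanged.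

Compound 4, `COc1cc(OC)c(OC)cc1/C=C/COC(=O)/C=C/c1ccc(F)cc1`, is the next compound in this row. Its difference from compound 3 is 4-fluorophenyl in place of 3-bromophenyl on a double-bonded chain carbon bound to a double-bonded chain carbon. The three measured steps bear on it directly, since each swaps an aryl group at the same place without effect, so the expected step is no change at the digits printed from compound 3 to compound 4 (within the scatter), that is, none beyond the scatter. Among the measured compounds shown here, compound 4 is therefore estimated to give 100% in this assay, within 85% to 100%; with no measured compound falling away from the common level, no firmer claim is possible.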

Compound 4, a percentage reported as activity, at one dose (the size of the read-out at that dose, not a potency): 100%
Beside the measured number, compound 4's estimate shows no gap at the digits printed, and the stated range covers the measured number.
By their numbers in this assay, from the lowest: compounds 1, 2, 3 and 4 (each within the scatter of the next).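

Compound 4 brings a new kind of change at this position, fluoro in place of bromo on an aromatic carbon, and in this assay it gives no change at the digits printed from compound 2 to compound 4 (within the scatter) as an exchange of one halogen for another. The 4-fluorophenyl group also gives no change at the digits printed from compound 3 to compound 4 (within the scatter) against the 3-bromophenyl group and no change at the digits printed from compound 1 to compound 4 (within the scatter) against the 3,4-dimethoxyphenyl group, so all four aryl groups on a double-bonded chain carbon bound to a double-bonded chain carbon stand level. Nothing measured alongside these numbers offers a reason for this flat result.

With all four compounds at one level, these compounds do not show any group at this place that moves the read-out. From the compounds shown here alone, it stays open whether an aryl group carrying an amine or a carboxylic acid, or a plain longer alkyl chain in place of the aryl group, would change the number.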